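From pyrrolidin-1-yl to piperidin-1-yl on a short-lived compound

The compounds below may be only part of what the source reports. "The series", "measured", "known", "first", "only" and "open" are said of these compounds alone.

Compound 1 `CN(C)c1ccc2cc(-c3cn(C)c4ccccc34)c(N)nc2c1` gives 0.26 h
Compound 2 `CNc1ccc2cc(-c3cn(C)c4ccccc34)c(N)nc2c1` gives 1.3 h
Compound 3 `Cn1cc(-c2cc3ccc(N4CCCC4)cc3nc2N)c2ccccc21` gives < 0.1 h as a limit, not a number

These values come from an ADME assay on microsomes from liver (Mus musculus) for metabolic stability, read by HPLC, with a stated time of 4 h (on this read-out higher numbers stand for a longer-lived compound and lower numbers for a shorter-lived compound), and the three compounds share one core. Compound 3 stands lowest of the three, at the limit of < 0.1 h in this assay, at which 1 of the 3 values shown sits, and this is a limit, not a measured number.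

Compound 4 `Cn1cc(-c2cc3ccc(N4CCCCC4)cc3nc2N)c2ccccc21` keeps the shared core and carries piperidin-1-yl in place of pyrrolidin-1-yl on an aromatic carbon. Two measured steps changed the group on that same carbon to pyrrolidin-1-yl. They gave an at least 2.6-fold lower number from compound 1 to compound 3 (0.41 log units; beyond the scatter) and an at least 13-fold lower number from compound 2 to compound 3 (1.11 log units; beyond the scatter) in the same direction. Hydrogen in place of methyl on the attached nitrogen gave a 5.0-fold higher number from compound 1 to compound 2 (0.70 log units; beyond the scatter) in the opposite direction. For the measured compounds named here, no measured step swaps one ring for the other, so compound 3 is the closest guide to compound 4. The expected step is a number no lower from compound 3 to compound 4 (the limit leaves the size open) in this assay and no change beyond the scatter is expected in either direction. Compound 4 is estimated at 0.1 h (expected range 0.05 h to 0.3 h).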

Compound 4, half-life: 0.8 h
Compound 4: the middle estimate sits 8.0-fold (0.90 log units) below what was measured; the measured number lies above the stated range.
By their numbers in this assay, from the lowest: compound 1; then compounds 4 and 2 (each within the scatter of the next). At a limit, below all of these: compound 3.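

In this assay, the ring size of the amine on this aromatic carbon matters: piperidin-1-yl in place of pyrrolidin-1-yl gives an at least 8.0-fold higher number from compound 3 to compound 4 (0.90 log units; beyond the scatter), so the short life of compound 3 does not extend to every ring amine here. On these data alone, the true size of that step stays open because compound 3 stands at a limit: the limit of < 0.1 h in this assay, at which 1 of the 4 values shown sits. Piperidin-1-yl in place of dimethylamino gives a 3.1-fold higher number from compound 1 to compound 4 (0.49 log units; beyond the scatter), while piperidin-1-yl in place of methylamino gives a 1.6-fold lower number from compound 2 to compound 4 (0.21 log units; within the scatter), so the last two groups cannot be told apart in this read-out.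

As far as these compounds go, whether azepan-1-yl or morpholin-4-yl on the same carbon would behave like piperidin-1-yl or like pyrrolidin-1-yl remains open. The compounds shown also do not reveal which part of each molecule is lost in the microsomes.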